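This account rests on a few compounds, and the source may have more. Where it says the series, first, only, none or still open, it means among the compounds named here.

Among the measured compounds shown here, the two compounds measured so far share one core. Compound 1 `COc1ccc(Cc2ccc3ccccc3c2O)cc1` gives, in an assay on RBL-1 cells with Polyunsaturated fatty acid 5-lipoxygenase (Rattus norvegicus) as the target (on this read-out lower numbers stand for stronger inhibition and higher numbers for weaker inhibition), a value of 75 nM. Compound 2 `Oc1c(Cc2ccc(OCc3ccccc3)cc2)ccc2ccccc12` gives in this assay a value of 72 nM. For the measured compounds named here, the single step between them, a 1.0-fold lower number from compound 1 to compound 2 (0.02 log units; within the scatter), shows that exchanging methoxy for benzyloxy on this core leaves the result essentially unchanged. Among the two numbers recorded, compound 2 shows the lowest, with compound 1 lying within the scatter of it, so no order can be read between them.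

Compound 3 `Oc1c(Cc2ccc(Cl)cc2)ccc2ccccc12` is not yet measured. It differs from compound 2 by chloro in place of benzyloxy on an aromatic carbon. Going by the values given here, no measured step covers this exchange; the only step available, a 1.0-fold lower number from compound 1 to compound 2 (0.02 log units; within the scatter), concerns the same position but a different pair of groups, and it was within the scatter. The record therefore offers no ground to expect a change beyond the scatter in this assay, and the step from compound 2 to compound 3 is expected to be a 1.4-fold higher number from compound 2 to compound 3 (0.14 log units; within the scatter). On that basis compound 3 is estimated to give 100 nM in this assay, with a range from 35 nM to 300 nM.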

Compound 3, half-maximal inhibitory concentration: 39 nM
The estimate for compound 3 lay 2.6-fold (0.41 log units) above the measured number; the measured number falls inside the stated range.
By their numbers in this assay, from the lowest: compounds 3, 2 and 1 (each within the scatter of the next).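

In this assay, the exchange on this aromatic carbon takes away benzyloxy, with its 8 heavy atoms, its six-membered aromatic ring and its hydrogen-bond acceptor, and leaves a single chlorine, yet it gives only a 1.8-fold lower number from compound 2 to compound 3 (0.27 log units; within the scatter) on the shared core. The exchange of methoxy for chloro gives a 1.9-fold lower number from compound 1 to compound 3 (0.28 log units; within the scatter) and so also stays inside the usual spread of repeated measurements. Among the compounds shown here, the earlier pair compared only two oxygen-linked groups, whereas these steps show that a group with no hydrogen-bond acceptor and no ring gives a number that cannot be told apart from those of compound 1 and compound 2, and no evidence is available to explain this result.

The three compounds leave open whether any group on this carbon would produce a step beyond the scatter, for instance an amine, a carboxylic acid or a longer alkyl chain. They also leave open whether the result would hold with chloro moved elsewhere on the same ring, or with the hydroxy group on the shared core replaced by methoxy.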